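The source may hold more compounds than are shown below. What is called first, only, known or untested is meant among the compounds shown, and "the series" means these compounds.

Measured so far in a functional assay on HepG2 cells (Homo sapiens) for cytotoxicity, read by MTT assay, with a stated time of 24 h; a higher number here means a weaker inhibitor, a lower number a stronger inhibitor:
compound 1 `O=C1/C(=C/c2cccc(F)c2)CN(S(=O)(=O)c2ccccc2)C/C1=C\c1cccc(F)c1`: 3400 nM
compound 2 `O=C1/C(=C/c2cccc(F)c2)CN(S(=O)(=O)c2ccc(O[N+](=O)[O-])cc2)C/C1=C\c1cccc(F)c1`: 8100 nM
compound 3 `O=C1/C(=C/c2cccc(F)c2)CN(S(=O)(=O)c2ccc(Cl)cc2)C/C1=C\c1cccc(F)c1`: 13100 nM

Compound 3 has the highest number of the three. Its gap to compound 2 is within the scatter, a 1.6-fold higher number from compound 2 to compound 3 (0.21 log units; within the scatter), while against compound 1 it lies beyond it, a 3.9-fold higher number from compound 1 to compound 3 (0.59 log units; beyond the scatter). Compound 2 also sits above compound 1, a 2.4-fold higher number from compound 1 to compound 2 (0.38 log units; beyond the scatter).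

Compound 4 `N#Cc1ccc(S(=O)(=O)N2C/C(=C\c3cccc(F)c3)C(=O)/C(=C/c3cccc(F)c3)C2)cc1` carries cyano in place of chloro on an aromatic carbon. For the measured compounds named here, the only measured step that bears on exchanging one group on that aromatic carbon for another is the chloro-for-nitrooxy step, which stayed within the scatter. For compound 4 the step expected in this assay is therefore a 1.3-fold lower number from compound 3 to compound 4 (0.12 log units; within the scatter), in no direction beyond the scatter. Compound 4 is estimated at 10000 nM, with a range of 4000 nM to 30000 nM.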

Compound 4, half-maximal inhibitory concentration: 2600 nM
For compound 4 the middle estimate is 3.8-fold (0.59 log units) above the measured one; measured number outside the range, below it.
By their numbers in this assay, from the lowest: compounds 4 and 1 (each within the scatter of the next); then compounds 2 and 3 (each within the scatter of the next).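

In this assay this aromatic carbon proves more sensitive to the choice of group than the chloro-for-nitrooxy exchange suggested: cyano brings (a 5.0-fold lower number from compound 3 to compound 4 (0.70 log units; beyond the scatter)) and (a 3.1-fold lower number from compound 2 to compound 4 (0.49 log units; beyond the scatter)). Unlike chloro and nitrooxy, cyano stays level with hydrogen (a 1.3-fold lower number from compound 1 to compound 4 (0.12 log units; within the scatter)), so a group at this carbon does not of itself raise the number among these compounds. No measurement shown accounts for the difference among these groups.

Going by these compounds, an amine, a carboxylic acid or a methoxy group at this carbon remains open. On these data alone, whether the cyano result carries over to other groups on the shared core also remains open.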